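Extending the methoxy on the shared core of compound 2

This account rests on a few compounds, and the source may have more. Where it says the series, first, only, none or still open, it means among the compounds named here.

Measured compounds:
- compound 1: `COc1ccc(S(=O)(=O)N(CCn2cc(CCCF)nn2)[C@@H](C(=O)NO)C(C)C)cc1`, 0.07 nM
- compound 2: `COc1ccc(S(=O)(=O)N(CCn2cc(CCCCOc3cccnc3F)nn2)[C@@H](C(=O)NO)C(C)C)cc1`, 0.3 nM
- compound 3: `COc1ccc(S(=O)(=O)N(CCn2cc(CN(C)S(=O)(=O)c3ccc(F)cc3)nn2)[C@@H](C(=O)NO)C(C)C)cc1`, 3 nM

In an assay on isolated protein for inhibition of matrix metalloproteinase-9 (Homo sapiens), read by fluorescence, with a stated time of 30 min (on this read-out lower numbers stand for stronger inhibition and higher numbers for weaker inhibition), compound 2 sits in the middle of the three numbers, with compound 1 giving the lowest and compound 3 the highest. The steps away from it are a 4.3-fold higher number from compound 1 to compound 2 (0.63 log units; beyond the scatter) and a 10-fold higher number from compound 2 to compound 3 (1.00 log units; beyond the scatter), and between the outer pair a 43-fold higher number from compound 1 to compound 3 (1.63 log units; beyond the scatter). All three steps change the group carried on the triazole chain.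

Compound 4, `CC(C)[C@H](C(=O)NO)N(CCn1cc(CCCCOc2cccnc2F)nn1)S(=O)(=O)c1ccc(OCCF)cc1`, is instead altered at the other end of the core. The change is fluoromethyl in place of hydrogen on a saturated chain carbon bound to an oxygen on an aromatic ring; read one bond further out, methoxy becomes 2-fluoroethoxy. Among the measured compounds shown here, no measured step touches this place, so nothing here shows how this assay answers a change on the aryl ether. Lacking such a comparison, the expected step is no change at the digits printed from compound 2 to compound 4 (within the scatter), in neither direction beyond the scatter. Compound 4 is therefore estimated at 0.3 nM, within 0.1 nM to 1 nM.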

Compound 4, half-maximal inhibitory concentration: 0.8 nM
Compound 4: the middle estimate sits 2.7-fold (0.43 log units) below what was measured; measured number inside the range.
By their numbers in this assay, from the lowest: compound 1; then compound 2; then compound 4; then compound 3.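

In this assay, going from methoxy to 2-fluoroethoxy gives a 2.7-fold higher number from compound 2 to compound 4 (0.43 log units; beyond the scatter), the first sign that this end of the shared core can shift the read-out. The direction is towards weaker inhibition, yet the step is only modest: adding fluoromethyl at this place costs some inhibition without removing it. Nothing available explains this rise.

From the compounds shown here alone, with a single replacement at this place, it stays open whether plain ethoxy, a longer chain such as 3-fluoropropoxy, or a free hydroxyl would move the number further, leave it alone or reverse the direction. Going by these compounds, it is also open whether 2-fluoroethoxy would bring a similar step on the core of compound 1, which carries a different group on its triazole chain.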